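The source may report more compounds than this note shows. Statements on the series, on what has been measured and on what is new or still open speak of the compounds shown alone.

In a functional assay on DU-145 cells (Homo sapiens) for inhibition, read by trypan blue exclusion, with a stated time of 96 h (a higher number here means a weaker inhibitor of growth, a lower number a stronger inhibitor of growth), compound 1 (`Cc1ccc(S/C(=C/c2ccc(Cl)cc2)C(=O)c2ccc(Br)cc2)cc1`) gives 10000 nM and stands level with compound 2 (`O=C(/C(=C\c1ccc(Cl)cc1)SCc1ccc(Cl)cc1)c1ccc(Br)cc1`), which gives 10000 nM at the digits shown. Together they hold the highest of the three numbers, and compound 3 (`O=C(/C(=C\c1ccc(Cl)cc1)Sc1ccc(Br)cc1)c1ccc(Br)cc1`) gives 1000 nM as the lowest of them. Compound 4 (`Cc1ccc(S/C(=C/c2ccc(F)cc2F)C(=O)c2ccc(Br)cc2)cc1`) departs from compound 1 by 2,4-difluorophenyl in place of 4-chlorophenyl on a double-bonded chain carbon bound to a double-bonded chain carbon in one place, 2,4-difluorophenyl in place of 4-chlorophenyl on a double-bonded chain carbon bound to a double-bonded chain carbon. Within the data shown here, none of the measured steps touches that place. The swap on sulfur gave no change at the digits printed from compound 1 to compound 2 (within the scatter) with nothing gained, while a 10-fold lower number from compound 1 to compound 3 (1.00 log units; beyond the scatter) and a 10-fold lower number from compound 2 to compound 3 (1.00 log units; beyond the scatter) were modest and lay elsewhere on the molecule. These steps bear on the question only indirectly, showing how far the numbers have moved within this small set for changes at other places. Among the measured compounds shown here, with no measured step at the changed place, no shift beyond the scatter is expected. The estimated step is a 1.4-fold lower number from compound 1 to compound 4 (0.15 log units; within the scatter) in this assay with only a slight lean towards a lower number. Compound 4 is expected at 7000 nM with an estimated range from 1500 nM to 20000 nM for the measurement still to come.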

Compound 4, concentration for 50% growth inhibition: > 100000 nM
Compound 4 was reported as a limit; the forecaster's own chance of this, stated with the estimate: 20%; middle value at least 14-fold (1.15 log units) from the limit.
By their numbers in this assay, from the lowest: compound 3; then compounds 1 and 2 (each within the scatter of the next). At a limit, above all of these: compound 4.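

The reading for compound 4 in this assay is a limit of the assay and not a number: the limit of > 100000 nM in this assay, at which 1 of the 4 values shown sits. Among these compounds, this gives the first measured step at this place, on a double-bonded chain carbon bound to a double-bonded chain carbon, and it reads an at least 10-fold higher number from compound 1 to compound 4 (1.00 log units; beyond the scatter). Among the compounds shown here, the earlier steps all lay elsewhere on the molecule and none raised the number beyond the scatter, so this pair is the first to show that a single change of 4-chlorophenyl to 2,4-difluorophenyl can take growth inhibition well out of the range of the other compounds in this set.

The compounds shown leave open whether the loss goes with the departure of the chlorine or with the arrival of the two fluorines, and how other groups would fare on that aromatic ring, such as a single fluorine, a methoxy group, an amine or a carboxylic acid. They also leave open whether 2,4-difluorophenyl would give the same result on the background of compound 3, which carries 4-bromophenyl on the sulfur and holds the lowest number of the set at 1000 nM.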